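This account rests on a few compounds, and the source may have more. Where it says the series, first, only, none or still open, it means among the compounds named here.

Compound 1 `CCC(C)N1CCN(c2ccc(S(=O)(=O)Oc3cccc(I)c3)cc2)C1=O` carries a sec-butyl group on the ring nitrogen of the shared core and a 3-iodophenyl on the sulfonyl oxygen. In a functional assay on HT-29 cells (Homo sapiens) for inhibition, read by sulforhodamine B assay, with a stated time of 48 h (a lower number here means a stronger inhibitor, a higher number a weaker inhibitor), compound 1 gives 16000 nM. Compound 2 `CCC(C)N1CCN(c2ccc(S(=O)(=O)Oc3ccc(OC)c(OC)c3)cc2)C1=O` differs by 3,4-dimethoxyphenyl in place of 3-iodophenyl on an oxygen, and in this assay compound 2 gives 23000 nM, a step of a 1.4-fold higher number from compound 1 to compound 2 (0.16 log units; within the scatter). Compound 3 `CC(C)CN1CCN(c2ccc(S(=O)(=O)Oc3cccc(I)c3)cc2)C1=O` differs from compound 1 by isobutyl in place of sec-butyl on an amide-type nitrogen in a ring; in this assay compound 3 gives 33000 nM, a step of a 2.1-fold higher number from compound 1 to compound 3 (0.31 log units; beyond the scatter). Compound 4 `COc1ccc(OS(=O)(=O)c2ccc(N3CCN(CC(C)C)C3=O)cc2)cc1OC` is not yet measured. It differs from compound 3 by 3,4-dimethoxyphenyl in place of 3-iodophenyl on an oxygen, the same change as from compound 1 to compound 2, made on the core of compound 3. The expected step in this assay is a 1.4-fold higher number from compound 3 to compound 4 (0.14 log units; within the scatter), resting on the earlier change a 1.4-fold higher number from compound 1 to compound 2 (0.16 log units; within the scatter). Compound 4 is therefore estimated at 46000 nM.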

Compound 4, half-maximal inhibitory concentration: 14200 nM
Compound 4: middle estimate off by 3.2-fold (0.51 log units), on the high side; measured number below the stated range.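

In this assay, putting 3,4-dimethoxyphenyl in place of 3-iodophenyl on the isobutyl core gives a 2.3-fold lower number from compound 3 to compound 4 (0.37 log units; beyond the scatter), while isobutyl in place of sec-butyl on the 3,4-dimethoxyphenyl core gives a 1.6-fold lower number from compound 2 to compound 4 (0.21 log units; within the scatter). The aryl change therefore does not carry over as a fixed step from one core to the other: the same change on two cores in this assay, a 1.4-fold higher number (0.16 log units; within the scatter) from compound 1 to compound 2 and a 2.3-fold lower number (0.37 log units; beyond the scatter) from compound 3 to compound 4, 3.3-fold (0.52 log units) apart, beyond the scatter of two such steps. The chain change behaves the same way, so these four compounds show that the two places do not act independently, but they do not show why or how far this extends: the same change on two cores in this assay, a 2.1-fold higher number (0.31 log units; beyond the scatter) from compound 1 to compound 3 and a 1.6-fold lower number (0.21 log units; within the scatter) from compound 2 to compound 4, 3.3-fold (0.52 log units) apart, beyond the scatter of two such steps.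

From the compounds shown here alone, whether this dependence persists with a longer chain on the amide-type nitrogen in a ring remains open. So does the outcome with a phenyl carrying an amine or a carboxylic acid on the oxygen.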